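Trifluoromethyl on the Phenylpiperazine Ring of a New Core

The compounds below may be only part of what the source reports. "The series", "measured", "known", "first", "only" and "open" are said of these compounds alone.

Measured compounds:
- Compound 1 `O=C1C2CCCCN2C(=O)N1CN1CCN(c2ccccc2)CC1`: in an assay on isolated protein for binding affinity to Adrenergic receptor alpha-1 (Rattus norvegicus), read by radioligand binding (on this read-out lower numbers stand for stronger inhibition and higher numbers for weaker inhibition), compound 1 gives only a limit, > 1000 nM.
- Compound 2 `O=C1C2CCCCN2C(=O)N1CN1CCN(c2cccc(C(F)(F)F)c2)CC1`: in this assay compound 2 likewise gives only a limit, > 1000 nM.
- Compound 3 `O=C1C2CCCN2C(=O)N1CCCN1CCN(c2ccccc2)CC1`: in this assay compound 3 gives 15.4 nM.

Compound 1 and compound 2 share one core and differ by trifluoromethyl in place of hydrogen on an aromatic carbon. Both values are limits of the assay, so the step that the two limits leave unreadable from compound 1 to compound 2 cannot be read, and this is stated with it: the limit of > 1000 nM in this assay, at which 2 of the 3 values shown sit. Within the data shown here, compound 3 carries a different core, and the difference between the two cores is not broken down here; its value is the only number among the three.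

Compound 4 `O=C1C2CCCN2C(=O)N1CCCN1CCN(c2cccc(C(F)(F)F)c2)CC1` is not yet measured. It differs from compound 3 by trifluoromethyl in place of hydrogen on an aromatic carbon, the same change as that from compound 1 to compound 2, and the only two occurrences of it among these compounds. The earlier occurrence gives no readable size, so the expectation for compound 4 rests on compound 3 alone, whose value 15.4 nM is the starting point, and on the absence of any readable direction from the earlier pair. Compound 4 is expected to lie close to compound 3, with an estimated step of a 1.3-fold higher number from compound 3 to compound 4 (0.11 log units; within the scatter). Compound 4 is therefore estimated at 20 nM, between 5 nM and 80 nM.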

Compound 4, inhibition constant: 109 nM
Compound 4: the middle estimate sits 5.5-fold (0.74 log units) below what was measured; the measured number lies above the stated range.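

In this assay, trifluoromethyl in place of hydrogen on an aromatic carbon, meta to a large group, gives a 7.1-fold higher number from compound 3 to compound 4 (0.85 log units; beyond the scatter), so on the core of compound 3 the change weakens inhibition by more than the usual scatter of repeated measurements. This is the only readable size for the change among the compounds shown, since the step on the core of compound 1 cannot be read, and whether the effect carries from one core to the other therefore remains unknown: the limit of > 1000 nM in this assay, at which 2 of the 4 values shown sit A single readable step on a single core establishes no rule for this change, and it shows neither that the same direction nor that the same size would hold on another core.

The compounds shown leave open whether a chlorine atom or a methoxy group in place of trifluoromethyl, on the same aromatic carbon, would give a step of similar size on the core of compound 3. They also leave open whether the step would persist with a longer chain on that core, and which part of the difference between the two cores governs the values seen.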